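Cyano to Chloro: Three Measurements and One Expectation

This account rests on a few compounds, and the source may have more. Where it says the series, first, only, none or still open, it means among the compounds named here.

Three compounds from one series have been run in an ADME assay on microsomes from liver (Homo sapiens) for metabolic stability, tested at 2.5 uM; on this read-out higher numbers stand for fast clearance and lower numbers for slow clearance. Compound 1 `N#Cc1ccc2c(-c3ccc(Cl)cc3)c(S(=O)(=O)c3ccc(F)cc3)cnc2c1` gives 0.01 mL/min. Compound 2 `N#Cc1ccc2ncc(S(=O)(=O)c3ccc(F)cc3)c(-c3ccc(Cl)cc3)c2c1` is built from the same atoms joined differently; the difference between the two cores is not broken down here. In this assay compound 2 gives 0.01 mL/min. Compound 3 `O=S(=O)(c1ccc(F)cc1)c1cnc2ccc(Cl)cc2c1-c1ccc(Cl)cc1` gives 0.01 mL/min. Compound 3 arises from compound 2 by chloro in place of cyano on an aromatic carbon, and that step is no change at the digits printed from compound 2 to compound 3 (within the scatter). All three values sit level with one another within the usual scatter, so none can be called slower or faster than another.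

Compound 4 `O=S(=O)(c1ccc(F)cc1)c1cnc2cc(Cl)ccc2c1-c1ccc(Cl)cc1` has not yet been measured. It arises from compound 1 by chloro in place of cyano on an aromatic carbon, the same change that turns compound 2 into compound 3, made at a place described in the same words. The expected step is no change at the digits printed from compound 1 to compound 4 (within the scatter) because the matching step was no change at the digits printed from compound 2 to compound 3 (within the scatter). Three level values and one flat step give little reason to expect anything else. On that basis compound 4 is expected to give 0.01 mL/min in this assay, with a likely range from 0.005 mL/min to 0.02 mL/min.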

Compound 4, intrinsic clearance in a liver preparation (reported as CLH), per the amount of preparation that the assay uses: 0.21 mL/min
For compound 4 the middle estimate is 21-fold (1.32 log units) below the measured one, outside the stated range (above it).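

The cyano-to-chloro change does not carry over unchanged from one core to the other in this assay: the same change on two cores in this assay, no change at the digits printed (within the scatter) from compound 2 to compound 3 and a 21-fold higher number (1.32 log units; beyond the scatter) from compound 1 to compound 4, 21-fold (1.32 log units) apart, beyond the scatter of two such steps. The new result is a 21-fold higher number from compound 1 to compound 4 (1.32 log units; beyond the scatter), and it shows that a flat step on one core is no safe guide to the same step on a closely related core in this series. It does not show why the two cores part ways, and with a single pair on each core it cannot say whether the larger step would recur in other compounds built on the core of compound 1.

The compounds shown leave open how a methyl, a methoxy, an amine or a carboxylic acid in place of the cyano would fare on each core, and whether those groups would also give different steps on the two cores. They also leave open whether such a split belongs to this one swap alone or appears with other changes to the shared structure.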